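A few compounds are considered here, and "the series" means these few. Any claim that something is new, unique, unknown or untested is made for them only; others in the source may bear on it.

The series shares the core shown in compound 1 `CC(=O)N(C)c1ccc(Sc2ncc([C@@]3(C)COC(C)(C)O3)s2)cc1`, which in a functional assay on blood for inhibition of Polyunsaturated fatty acid 5-lipoxygenase (Homo sapiens) (on this read-out higher numbers stand for weaker inhibition and lower numbers for stronger inhibition), gives 70 nM. Compound 2 `CC(=O)c1ccc(Sc2ncc([C@@]3(C)COC(C)(C)O3)s2)cc1` gives 390 nM, and compound 3 `C/C(=N\O)c1ccc(Sc2ncc([C@@]3(C)COC(C)(C)O3)s2)cc1` gives 130 nM. Compound 3 thus stands second highest of the three numbers: its nearest neighbour is compound 1, a 1.9-fold higher number from compound 1 to compound 3 (0.27 log units; within the scatter), within the scatter, and its furthest is compound 2, a 3.0-fold lower number from compound 2 to compound 3 (0.48 log units; beyond the scatter), beyond the scatter.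

Compound 4 `C/C(=N\OCC#N)c1ccc(Sc2ncc([C@@]3(C)COC(C)(C)O3)s2)cc1` differs from compound 3 by cyanomethyl in place of hydrogen on an oxygen. For the measured compounds named here, no measured step touches the oxygen whose other neighbour is the double-bonded nitrogen; the two steps that reach compound 3, a 1.9-fold higher number from compound 1 to compound 3 (0.27 log units; within the scatter) and a 3.0-fold lower number from compound 2 to compound 3 (0.48 log units; beyond the scatter), exchange the whole group on the aromatic carbon and are modest or within the scatter, and a 5.6-fold higher number from compound 1 to compound 2 (0.75 log units; beyond the scatter) likewise swaps whole groups. With nothing in the measured steps bearing directly on this change, the expected step in this assay is none beyond the scatter, a 1.2-fold higher number from compound 3 to compound 4 (0.06 log units; within the scatter). Compound 4 is therefore estimated at 150 nM, with a range from 50 nM to 450 nM.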

Compound 4, half-maximal inhibitory concentration: 30 nM
Compound 4: the middle estimate sits 5.0-fold (0.70 log units) above what was measured; the measured number lies below the stated range.
By their numbers in this assay, from the lowest: compound 4; then compounds 1 and 3 (each within the scatter of the next); then compound 2.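

In this assay, for the compounds shown here, the oxygen whose other neighbour is the double-bonded nitrogen tolerates substitution: cyanomethyl in place of hydrogen there gives a 4.3-fold lower number from compound 3 to compound 4 (0.64 log units; beyond the scatter) as the first measured change at this atom. The extended group on the aromatic carbon also outperforms both earlier kinds of group, with a 13-fold lower number from compound 2 to compound 4 (1.11 log units; beyond the scatter) against the acetyl group and a 2.3-fold lower number from compound 1 to compound 4 (0.37 log units; beyond the scatter) against the acetyl(methyl)amino group, so compound 4 has the lowest number of the series, beyond the scatter from each of the other compounds. No measurement on hand accounts for this gain.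

The compounds shown leave open whether the gain depends on the nitrile or would follow from other groups on this oxygen. A methyl, a longer nitrile-bearing chain or a carboxylic acid at this oxygen would help separate these possibilities.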